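Sulfur for Selenium in a Cytotoxicity Series

The source may hold more compounds than are shown below. What is called first, only, known or untested is meant among the compounds shown, and "the series" means these compounds.

Measured so far:
Compound 1 `C[Se]/C(=N\C(=O)c1cccs1)NC(=O)c1cccs1` gives > 100000 nM in a functional assay on MCF7 cells (Homo sapiens) for cytotoxicity, read by MTT assay, with a stated time of 72 h (on this read-out lower numbers stand for higher toxicity in this test and higher numbers for lower toxicity in this test), which is a limit of the assay.
Compound 2 `CS/C(=N\C(=O)c1ccno1)NC(=O)c1ccno1` gives > 100000 nM in this assay, likewise a limit.
Compound 3 `C[Se]/C(=N\C(=O)c1sccc1Cl)NC(=O)c1sccc1Cl` gives > 100000 nM in this assay, again a limit.

Compound 3 thus stands where every measured member of this set stands: none of the three has a number of its own, and all three sit at the limit of > 100000 nM in this assay, at which 3 of the 3 values shown sit. Going by the values given here, no pair of measured compounds differs in only one place, so no measured step is available, and nothing in the values separates compound 3 from compound 1 or compound 2.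

Compound 4 `CS/C(=N\C(=O)c1sccc1Cl)NC(=O)c1sccc1Cl` is the unmeasured partner of compound 3. It differs from compound 3 by a group of 2 heavy atoms (1 carbon, 1 sulfur; no ring) in place of a group of 2 heavy atoms (1 carbon, 1 selenium; no ring), on a carbon with a double bond to nitrogen. The methylsulfanyl group enters where the selenium-containing group leaves, on a carbon with a double bond to nitrogen whose other neighbours are two amide-type nitrogens; the rest of the molecule is kept.

Among the compounds with values here, with compound 3 at a limit and no step in hand, the expected step in this assay is none beyond the scatter, and the estimate for compound 4 follows as a number no higher from compound 3 to compound 4 (the limit leaves the size open). Compound 4 is therefore expected to give about 100000 nM in this assay, with a range from 30000 nM to 300000 nM, most likely reported again only as a limit.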

Compound 4, concentration lethal to 50% of the cells: > 100000 nM
Compound 4 gave a limit, no number; the forecaster's own chance of this, stated with the estimate: 85%; the middle value sits exactly at the limit.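

No new step can be read: compound 3 and compound 4 both give only a limit, so the change from the selenium-containing group to methylsulfanyl has no readable size in this assay: the limit of > 100000 nM in this assay, at which 4 of the 4 values shown sit.

The compounds shown leave open how these two groups compare in this assay, and what number any of the four compounds would have.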